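The compounds below may be only part of what the source reports. "The series", "measured", "known", "first", "only" and "open" are said of these compounds alone.

Compound 2 `N/C(=N\NC(=S)N1CCCCC1)c1ccccn1` gives 86.5% in a functional assay on A-375 cells (Homo sapiens) for cytotoxicity, read by MTT assay, with a stated time of 72 h, tested at 3 uM (a higher number here means more inhibition of growth at the concentration tested, a lower number less inhibition of growth), and compound 1 `N/C(=N\NC(=S)N1CCSCC1)c1ccccn1` gives 80% in this assay, so the two lie within the scatter of each other. Among the compounds with values here, the one step measured so far, a number 6.5 percentage points higher from compound 1 to compound 2 (within the scatter), swapped the ring on the thiocarbonyl carbon and left the shared core untouched. Compound 3 `Cc1cccc(/C(N)=N/NC(=S)N2CCCCC2)n1` differs from compound 2 by methyl in place of hydrogen on an aromatic carbon. Within the data shown here, no measured step touches that ring, so nothing in hand points to a shift beyond the scatter. The step expected is a number 4.5 percentage points lower from compound 2 to compound 3 (within the scatter). Compound 3 is estimated at 82%, within a range from 65% to 95%.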

Compound 3, percent growth inhibition at one concentration: 63.2%
Beside the measured number, compound 3's estimate is 18.8 percentage points above it; measured number outside the range, below it.
By their numbers in this assay, from the lowest: compound 3; then compounds 1 and 2 (each within the scatter of the next).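

In this assay, the aromatic carbon next to the ring nitrogen proves sensitive: methyl in place of hydrogen there gives a number 23.3 percentage points lower from compound 2 to compound 3 (beyond the scatter). The earlier step, a number 6.5 percentage points higher from compound 1 to compound 2 (within the scatter), changed the other ring, so this is the first change shown to move the number beyond the scatter. Nothing measured here explains the drop.

From the compounds shown here alone, whether an ethyl, methoxy or amino group on this carbon would lower the number too remains open. So does whether methyl on another carbon of this ring would have the same effect.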